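A five-membered ring enters at compound 3

The compounds below may be only part of what the source reports. "The series", "measured", "known", "first", "only" and "open" are said of these compounds alone.

Measured in a functional assay on NUGC-3 cells (Homo sapiens) for antiproliferative activity, read by sulforhodamine B assay; on this read-out higher numbers stand for weaker inhibition of growth and lower numbers for stronger inhibition of growth:
Compound 1 `CC(C)(C)CCOc1cccc(O)c1C(=O)/C=C/c1ccc(O)cc1`: 3300 nM
Compound 2 `CCC(CC)COc1cccc(O)c1C(=O)/C=C/c1ccc(O)cc1`: 1960 nM

In this assay, among the compounds with values here, compound 2 gives 1960 nM and so stands level, within the scatter, with compound 1, the only other measured compound. No order can be drawn between the two.

Compound 3 `O=C(/C=C/c1ccc(O)cc1)c1c(O)cccc1OCCC1CCCC1` differs from compound 2 in one place (cyclopentylmethyl in place of pentan-3-yl on a saturated chain carbon bound to an oxygen on an aromatic ring). Cyclopentylmethyl stands in place of pentan-3-yl on a saturated chain carbon bound to an oxygen on an aromatic ring, so the chain now ends in a five-membered non-aromatic ring of carbon only.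

Within the data shown here, one measured step bears on this change: a 1.7-fold lower number from compound 1 to compound 2 (0.23 log units; within the scatter). That step exchanged the group at the same place and stayed small. Among the measured compounds shown here, it is the only guide, and no measured compound carries a ring in this group. On that single step, no change beyond the scatter is expected in this assay, in either direction. The expected step is a 1.0-fold higher number from compound 2 to compound 3 (0.01 log units; within the scatter). Compound 3 is estimated at 2000 nM, with an expected range of 900 nM to 4500 nM.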

Compound 3, concentration for 50% growth inhibition: 3200 nM
The estimate for compound 3 lay 1.6-fold (0.20 log units) below the measured number; low and high end bracket the measured number.
By their numbers in this assay, from the lowest: compounds 2, 3 and 1 (each within the scatter of the next).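

In this assay, within the data shown here, cyclopentylmethyl in place of pentan-3-yl gives a 1.6-fold higher number from compound 2 to compound 3 (0.21 log units; within the scatter) and so brings the first ring into this group without a change beyond the scatter. Cyclopentyl in place of tert-butyl, on a saturated chain carbon two bonds along the chain from an oxygen on an aromatic ring, gives a 1.0-fold lower number from compound 1 to compound 3 (0.01 log units; within the scatter) in the same assay, so this second comparison also stays within the scatter. Neopentyl, pentan-3-yl and cyclopentylmethyl therefore stand level at this place, and among these three carbon-only groups, the five-membered non-aromatic ring sets compound 3 apart from neither compound 1 nor compound 2. Nothing on hand gives a reason why these numbers stay together.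

The compounds shown leave open whether an amine, a carboxylic acid or a longer chain at this place would carry the number beyond the scatter in either direction. They also leave open whether a six-membered ring of carbon would stand level with the five-membered one, and whether the level standing of these groups would hold on cells other than those of this assay.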